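Butylsulfanyl for butoxy on the shared core

A few compounds are considered here, and "the series" means these few. Any claim that something is new, unique, unknown or untested is made for them only; others in the source may bear on it.

Measured in an ADME assay on CCRF-HSB-2 cells (Homo sapiens) for cytotoxicity, with a stated time of 7 days; a lower number here means that less compound is tolerated, a higher number that more compound is tolerated:
- compound 1 `CCCNc1nc(N)nc2c1ncn2/C=C1/CC1(CO)CO`: > 20000 nM (a limit)
- compound 2 `CCCCCCCCSc1nc(N)nc2c1ncn2/C=C1/CC1(CO)CO`: 60000 nM
- compound 3 `CCCCOc1nc(N)nc2c1ncn2/C=C1/CC1(CO)CO`: > 20000 nM (a limit)

Compound 3 has only a limit, > 20000 nM.

Compound 4 `CCCCSc1nc(N)nc2c1ncn2/C=C1/CC1(CO)CO` carries butylsulfanyl in place of butoxy on an aromatic carbon.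

The closest measured change is a step that the limit leaves unreadable from compound 2 to compound 3. The other two, a step that the two limits leave unreadable from compound 1 to compound 3 and a step that the limit leaves unreadable from compound 1 to compound 2, give no readable size either. Two of the three compounds sit at the limit of > 20000 nM in this assay, at which 2 of the 3 values shown sit. Among the measured compounds shown here, compound 2, the only measured compound with a sulfur-linked chain, gives 60000 nM, so a number in that region is expected for compound 4 as well.

The expected change is a step that the limit leaves unreadable from compound 3 to compound 4, with no firm direction. Compound 4 is expected at 40000 nM, with an estimated range of 12000 nM to 100000 nM.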

Compound 4, half-maximal cytotoxic concentration: 89000 nM
The estimate for compound 4 lay 2.2-fold (0.35 log units) below the measured number; the range from low to high includes it.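

Butylsulfanyl and octylsulfanyl on this aromatic carbon are not told apart in this assay: the step is a 1.5-fold higher number from compound 2 to compound 4 (0.17 log units; within the scatter). The two sulfur-linked chains therefore read alike, and a second readable number now stands for this linkage. The steps to compound 4 from compound 3 and from compound 1 cannot be read, and both of those compounds stand at a limit: the limit of > 20000 nM in this assay, at which 2 of the 4 values shown sit.

From the compounds shown here alone, whether sulfur, oxygen or nitrogen as the linking atom matters at this position stays open. So does the reading for a methylsulfanyl group, or for a chain ending in an amine or a carboxylic acid.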